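Acetoxy to azido at the side chain: notes on compound 4

The source may hold more compounds than are shown below. What is called first, only, known or untested is meant among the compounds shown, and "the series" means these compounds.

Measured compounds:
Compound 1, `CC(=O)OC/C1=C/C[C@](C)(CCC=C(C)C)/C=C/[C@@H](OC(=O)C=C(C)C)[C@](C)(O)/C=C/C1=O`, gives 2950 nM in a functional assay on SMMC-7721 cells (Homo sapiens) for antiproliferative activity, read by MTT assay, with a stated time of 48 h; on this read-out higher numbers stand for weaker inhibition and lower numbers for stronger inhibition.
Compound 2, `CC(C)=CCC[C@]1(C)/C=C/[C@@H](OC(=O)C=C(C)C)[C@](C)(O)/C=C/C(=O)/C(CN2CCN(C)CC2)=C\C1`, gives 2940 nM in this assay.
Compound 3, `CC[Si](CC)(CC)C/C1=C/C[C@](C)(CCC=C(C)C)/C=C/[C@@H](OC(=O)C=C(C)C)[C@](C)(O)/C=C/C1=O`, gives 3460 nM in this assay.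

Compound 1 stands second highest of the three numbers in this assay, but all three lie within the scatter of one another. The step of a 1.0-fold lower number from compound 1 to compound 2 (0.00 log units; within the scatter) is flat, the step of a 1.2-fold higher number from compound 1 to compound 3 (0.07 log units; within the scatter) is also within the scatter, and the same holds for a 1.2-fold higher number from compound 2 to compound 3 (0.07 log units; within the scatter). Across these three compounds the group on the saturated chain carbon bound to a double-bonded ring carbon has been exchanged between acetoxy, 4-methylpiperazin-1-yl and a triethylsilylmethyl-type group without any change beyond the scatter.

Compound 4, `CC(C)=CCC[C@]1(C)/C=C/[C@@H](OC(=O)C=C(C)C)[C@](C)(O)/C=C/C(=O)/C(CN=[N+]=[N-])=C\C1`, is the next member of this series. It differs from compound 1 as follows: azido in place of acetoxy on a saturated chain carbon bound to a double-bonded ring carbon.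

Both measured steps that start from compound 1 bear on this change, since each replaces the acetoxy group at the same place, and both stayed within the scatter. No step beyond the scatter is therefore expected for a 1.0-fold higher number from compound 1 to compound 4 (0.01 log units; within the scatter). Compound 4 is expected to give about 3000 nM in this assay, with a range from 1500 nM to 6500 nM.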

Compound 4, half-maximal inhibitory concentration: 3080 nM
Beside the measured number, compound 4's estimate is 1.0-fold (0.01 log units) below it, within the range that was stated.
By their numbers in this assay, from the lowest: compounds 2, 1, 4 and 3 (each within the scatter of the next).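

At the saturated chain carbon bound to a double-bonded ring carbon, the series now holds a group with no carbon: azido, with 1 hydrogen-bond acceptor, in place of acetoxy, with 2 hydrogen-bond acceptors, and in this assay this gives a 1.0-fold higher number from compound 1 to compound 4 (0.02 log units; within the scatter). Against the other two groups the picture is the same, with a 1.0-fold higher number from compound 2 to compound 4 (0.02 log units; within the scatter) and a 1.1-fold lower number from compound 3 to compound 4 (0.05 log units; within the scatter), so the four compounds now span groups of 3 to 7 heavy atoms at this place, with and without a ring, and no listed step leaves the scatter. No supporting measurement is available to account for this flat picture.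

Still open is whether any group at this place can move the number beyond the scatter, since a primary amine, a carboxylic acid or a longer alkyl chain does not appear among these compounds. From the compounds shown here alone, whether the same flat picture would hold on other cell lines or with a different exposure time also stays open, as the four values come from this one assay.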